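This account rests on a few compounds, and the source may have more. Where it says the series, first, only, none or still open, it means among the compounds named here.

Measured compounds:
Compound 1, `COCCCOc1ccnc(COc2ccc(CS(=O)(=O)c3nc4cc(OC(F)F)ccc4[nH]3)cc2OC)c1C`: 142 nM
Compound 2, `COc1ccc2[nH]c(S(=O)(=O)Cc3ccc(OCc4nccc(OCC(F)(F)F)c4C)c(OC)c3)nc2c1`: 1760 nM

In a functional assay on cells (Erythrocyte, Homo sapiens) (on this read-out higher numbers stand for weaker inhibition and lower numbers for stronger inhibition), compound 2 stands at 1760 nM, the higher of the two numbers recorded. Its nearest neighbour, compound 1, gives 142 nM in this assay, a gap beyond the usual scatter. Among the measured compounds shown here, the two differ in more than one place, so the values say only that compound 1 is the stronger inhibitor of the pair and nothing about which part of the structure accounts for it.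

Compound 3, `COc1cc(CS(=O)(=O)c2nc3cc(OC(F)F)ccc3[nH]2)ccc1OCc1nccc(OCC(F)(F)F)c1C`, has not yet been measured. It differs from compound 2 in a single place: difluoromethyl in place of methyl on an oxygen on an aromatic ring. The group that enters is the one carried on the core of compound 1, though compound 1 also carries a different chain on its far side, so no clean comparison is available.

For the measured compounds named here, with no single-change step to lean on, a modest move to a lower number is expected, a 2.5-fold lower number from compound 2 to compound 3 (0.40 log units; beyond the scatter), with the limits kept wide. Compound 3 is estimated to give 700 nM in this assay, within a range of 200 nM to 2500 nM.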

Compound 3, half-maximal inhibitory concentration: 1880 nM
Compound 3: middle estimate off by 2.7-fold (0.43 log units), on the low side, within the range that was stated.
By their numbers in this assay, from the lowest: compound 1; then compounds 2 and 3 (each within the scatter of the next).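

In this assay, methoxy to difluoromethoxy on the core gives a 1.1-fold higher number from compound 2 to compound 3 (0.03 log units; within the scatter), so with trifluoromethyl at the end of the chain these two groups cannot be told apart on an oxygen on an aromatic ring. The other single change, trifluoromethyl in place of 2-methoxyethyl on a saturated chain carbon bound to an oxygen on an aromatic ring, gives a 13-fold higher number from compound 1 to compound 3 (1.12 log units; beyond the scatter), a large step and the only one of the two that lies beyond the scatter. No measurement at hand offers an explanation for either result.

The compounds shown leave open whether methoxy and difluoromethoxy would also read alike in a compound carrying 2-methoxyethyl in place of trifluoromethyl, since only one of that pair appears with the 2-methoxyethyl group here. They also leave open how a longer ether chain, or an amine or a carboxylic acid at the end of the chain, would compare with 2-methoxyethyl and trifluoromethyl on this read-out.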